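Moving the Methyl Around the Benzyl Ring

This account rests on a few compounds, and the source may have more. Where it says the series, first, only, none or still open, it means among the compounds named here.

For the measured compounds named here, compound 1 `C/C(=N\Cc1cccc(C)c1)c1c(O)c2ccccc2oc1=O` is the only compound of the three measured that returns a number: in an assay on isolated protein for inhibition of myosin-2 (Bos taurus), read by spectrophotometry, with a stated time of 24 min (on this read-out higher numbers stand for weaker inhibition and lower numbers for stronger inhibition), compound 1 gives 4900 nM. Compound 2 `C/C(=N\CCO)c1c(O)c2ccccc2[nH]c1=O`, which carries a different core, sits at a limit of the assay, >= 100000 nM. Compound 3 `CCCCC/N=C(\C)c1c(O)c2ccccc2[nH]c1=O`, on that same core, also sits at a limit, >= 100000 nM. Going by the values given here, the single step between measured compounds, a step that the two limits leave unreadable from compound 2 to compound 3, therefore cannot be read, and the limit of >= 100000 nM in this assay, at which 2 of the 3 values shown sit, describes the state of the data for both of them. Compound 4 `C/C(=N\Cc1ccc(C)cc1)c1c(O)c2ccccc2oc1=O` is the rearranged partner of compound 1, with 4-methylphenyl in place of 3-methylphenyl on a saturated chain carbon bound to a double-bonded nitrogen. Among the compounds with values here, none of the measured steps bears on this change: the one step available concerns the other core and is unreadable, so no measured precedent exists for shifting the methyl on the benzyl ring. With nothing to suggest a move in either direction, the step of no change at the digits printed from compound 1 to compound 4 (within the scatter) is expected to stay within the usual scatter. Compound 4 is thus estimated at 4900 nM, in a range from 1500 nM to 16000 nM.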

Compound 4, half-maximal inhibitory concentration: 7900 nM
Compound 4: the middle estimate sits 1.6-fold (0.21 log units) below what was measured, within the range that was stated.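

In this assay, for the compounds shown here, the exchange of 3-methylphenyl for 4-methylphenyl on a saturated chain carbon bound to a double-bonded nitrogen gives a 1.6-fold higher number from compound 1 to compound 4 (0.21 log units; within the scatter) and so provides the first step in the set that can be read, the earlier one being hidden by two limits. On the core of compound 1, this read-out therefore does not separate the two methylphenyl groups at this place. Nothing shown accounts for the size of this step.

Going by these compounds, what a different group would do at this place stays open, whether a carboxylic acid, an amine or a methoxy group in place of the methyl on the ring. Also open, on these data alone, is whether either methylphenyl group on the core of compound 2 would return a number rather than a limit.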